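This account rests on a few compounds, and the source may have more. Where it says the series, first, only, none or still open, it means among the compounds named here.

Compound 2 `O=C1c2cccc([N+](=O)[O-])c2NC[C@@]12[C@H](c1ccc(Cl)cc1)[C@@H](c1ccccc1)N[C@]21C(=O)Nc2ccc(Br)cc21` gives 23000 nM in a functional assay on HeLa cells (Homo sapiens) for cytotoxicity, read by MTT assay, with a stated time of 72 h; on this read-out lower numbers stand for stronger inhibition and higher numbers for weaker inhibition. Among the three measured compounds it shows the highest number, yet both neighbours fall within the scatter: compound 1 `O=C1c2cccc([N+](=O)[O-])c2NC[C@@]12[C@H](c1ccc(Cl)cc1)[C@@H](c1ccccc1)N[C@]21C(=O)Nc2ccc(Cl)cc21` gives 18000 nM in this assay, and compound 3 `COc1ccc([C@@H]2[C@@H](c3ccccc3)N[C@]3(C(=O)Nc4ccc(Br)cc43)[C@]23CNc2c(cccc2[N+](=O)[O-])C3=O)cc1` gives 19000 nM in this assay. The step of a 1.3-fold higher number from compound 1 to compound 2 (0.11 log units; within the scatter) and the step of a 1.2-fold lower number from compound 2 to compound 3 (0.08 log units; within the scatter) are both too small to count as real differences.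

Compound 4 `O=C1c2cccc([N+](=O)[O-])c2NC[C@@]12[C@H](c1ccc(Cl)cc1)[C@@H](c1ccccc1)N[C@]21C(=O)Nc2ccc(F)cc21` differs from compound 2 by fluoro in place of bromo on an aromatic carbon. Among the measured compounds shown here, the only measured step touching this position, the exchange from compound 1 to compound 2, gave a 1.3-fold higher number from compound 1 to compound 2 (0.11 log units; within the scatter), which suggests that this halogen position tolerates exchange without a change beyond the scatter. For the measured compounds named here, no fluoro analogue has been measured at this position, so the expectation rests on that single step.

On this basis compound 4 is expected to give 20000 nM in this assay, with a range from 10000 nM to 40000 nM. The expected step is a 1.2-fold lower number from compound 2 to compound 4 (0.06 log units; within the scatter), meaning no change beyond the scatter.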

Compound 4, half-maximal inhibitory concentration: 25000 nM
The estimate for compound 4 lay 1.3-fold (0.10 log units) below the measured number, and the stated range covers the measured number.
By their numbers in this assay, from the lowest: compounds 1, 3, 2 and 4 (each within the scatter of the next).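

With fluoro in this place, the three halogens can now be compared directly on the same aromatic carbon of the shared core. In this assay, among the compounds shown here, the exchange of bromo for fluoro gives (a 1.1-fold higher number from compound 2 to compound 4 (0.04 log units; within the scatter)) and the exchange of chloro for fluoro gives (a 1.4-fold higher number from compound 1 to compound 4 (0.14 log units; within the scatter)), so the earlier single exchange of chloro for bromo is no longer the only evidence that this position tolerates a change of halogen. Nothing measured here explains why these exchanges leave the number within the scatter.

All three groups compared at this position are single halogen atoms, so the compounds shown leave open whether an amine, a carboxylic acid or a longer chain would be tolerated there as well. They also leave open what plain hydrogen at this carbon would give.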